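From 2-fluorobenzyl to 2,4-difluorobenzyl

The source may hold more compounds than are shown below. What is called first, only, known or untested is meant among the compounds shown, and "the series" means these compounds.

Three compounds share one core and differ only in where a single fluoro sits on the phenyl group. In a functional assay on Bel-7402 cells (Homo sapiens) for antiproliferative activity, read by MTT assay, with a stated time of 72 h (on this read-out lower numbers stand for stronger inhibition and higher numbers for weaker inhibition), compound 1 `C=C1C(=O)O[C@H]2[C@H]1CC/C(COC(=O)Cn1cc(F)c(=O)n(Cc3ccc(F)cc3)c1=O)=C\CC[C@@]1(C)O[C@@H]21` gives 2730 nM, compound 2 `C=C1C(=O)O[C@H]2[C@H]1CC/C(COC(=O)Cn1cc(F)c(=O)n(Cc3cccc(F)c3)c1=O)=C\CC[C@@]1(C)O[C@@H]21` gives 2530 nM, and compound 3 `C=C1C(=O)O[C@H]2[C@H]1CC/C(COC(=O)Cn1cc(F)c(=O)n(Cc3ccccc3F)c1=O)=C\CC[C@@]1(C)O[C@@H]21` gives 3770 nM. These numbers do not separate compound 3 from the other two: the data show a 1.4-fold higher number from compound 1 to compound 3 (0.14 log units; within the scatter) and a 1.5-fold higher number from compound 2 to compound 3 (0.17 log units; within the scatter). The remaining step, a 1.1-fold lower number from compound 1 to compound 2 (0.03 log units; within the scatter), tells the same story.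

Compound 4 `C=C1C(=O)O[C@H]2[C@H]1CC/C(COC(=O)Cn1cc(F)c(=O)n(Cc3ccc(F)cc3F)c1=O)=C\CC[C@@]1(C)O[C@@H]21` is compound 3 with one more fluoro: fluoro in place of hydrogen on an aromatic carbon. The 2-fluorobenzyl group becomes 2,4-difluorobenzyl, with fluoro in place of hydrogen on an aromatic carbon, meta to a fluoro group and para to a large group. For the measured compounds named here, no measured step adds a second fluoro, so the evidence is only indirect. Still, compound 4 carries the fluoro positions of both compound 1 and compound 3, and that pair shows a 1.4-fold higher number from compound 1 to compound 3 (0.14 log units; within the scatter). On this basis, no change beyond the scatter is expected in this assay. The expected step is a 1.3-fold lower number from compound 3 to compound 4 (0.10 log units; within the scatter). For compound 4, the estimated value is 3000 nM, with an expected range from 1700 nM to 5200 nM.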

Compound 4, half-maximal inhibitory concentration: 3670 nM
Estimate against measurement, compound 4: 1.2-fold (0.09 log units) below, within the range that was stated.
By their numbers in this assay, from the lowest: compounds 2, 1, 4 and 3 (each within the scatter of the next).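

For the compounds shown here, this pair gives the first direct reading of a second fluoro on the phenyl group: in this assay, going from 2-fluorobenzyl to 2,4-difluorobenzyl gives (a 1.0-fold lower number from compound 3 to compound 4 (0.01 log units; within the scatter)), so fluoro in place of hydrogen at this ring carbon leaves the number where it was. The comparisons with the two other single-fluoro compounds agree, with (a 1.3-fold higher number from compound 1 to compound 4 (0.13 log units; within the scatter)) and (a 1.5-fold higher number from compound 2 to compound 4 (0.16 log units; within the scatter)), so across these four compounds neither the place of a single fluoro nor the addition of a second one separates any compound from the rest. Nothing available here accounts for this flat picture.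

As far as these compounds go, whether a plain benzyl group with no fluoro, a chloro or methoxy group on the phenyl ring, or a longer chain in place of the benzyl group would move the number beyond the scatter remains open. Also open, from the compounds shown here alone, is whether the same flat picture would hold on cell lines other than this one, since all four compounds are compared here on a single read-out.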